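The source may report more compounds than this note shows. Statements on the series, on what has been measured and on what is new or still open speak of the compounds shown alone.

Working notes on the amide series

The shared core of compound 1 `Cc1ccccc1NC(=O)/C=C/c1coc2cc(O)ccc2c1=O` carries an amide whose nitrogen substituent is varied. In a functional assay on HeLa cells (Homo sapiens) for inhibition, read by MTT assay, with a stated time of 48 h (a lower number here means a stronger inhibitor, a higher number a weaker inhibitor), compound 1 gives 8670 nM. Compound 2 `Cc1ccc(CNC(=O)/C=C/c2coc3cc(O)ccc3c2=O)cc1` carries a benzyl-type group instead; in this assay compound 2 reaches only the limit > 100000 nM, so its standing is known as a bound and not as a number. Compound 3 `COc1ccc(NC(=O)/C=C/c2coc3cc(O)ccc3c2=O)cc1` likewise sits at the limit > 100000 nM in this assay. The steps of an at least 11-fold higher number from compound 1 to compound 2 (1.06 log units; beyond the scatter) and an at least 11-fold higher number from compound 1 to compound 3 (1.06 log units; beyond the scatter) are both large and both end at the limit of > 100000 nM in this assay, at which 2 of the 3 values shown sit, while the step that the two limits leave unreadable from compound 2 to compound 3 cannot be read.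

Compound 4 `O=C(/C=C/c1coc2cc(O)ccc2c1=O)NCc1ccc(F)cc1F` differs from compound 2 by 2,4-difluorophenyl in place of 4-methylphenyl on a saturated chain carbon bound to an amide-type nitrogen. Among the compounds with values here, no measured step covers a change of this kind within the benzyl-type series; the only measured steps run from compound 1 outward and both end at the limit, so they give no direction for compound 4. The expected step of a number no higher from compound 2 to compound 4 (the limit leaves the size open) in this assay is therefore none beyond the scatter, with compound 4 most likely again at the limit. Compound 4 is estimated at 100000 nM, in the range 30000 nM to 300000 nM.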

Compound 4, half-maximal inhibitory concentration: > 100000 nM
Compound 4: no number, only a limit; the forecaster's own chance of this, stated with the estimate: 70%; the middle value lies on the limit itself.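

In this assay compound 4 gives only a limit, > 100000 nM, and not a number. Compound 2 also stands at a limit, so no step from compound 2 to compound 4 can be read: the limit of > 100000 nM in this assay, at which 3 of the 4 values shown sit.

Going by these compounds, whether 2,4-difluorophenyl in place of 4-methylphenyl changes the inhibition at all remains open.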